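The source may report more compounds than this note shows. Statements on the series, on what has been measured and on what is new or still open speak of the compounds shown alone.

Compound 3 `CC(=O)Nc1cccc2c(-c3cccc(NC(=O)c4ccc(C)c(C)c4)c3)ccnc12` carries an acetyl on a nitrogen of the shared core and a 3,4-dimethylphenyl amide. In a functional assay on A375P cells (Homo sapiens) for antiproliferative activity, read by MTT assay, with a stated time of 48 h (on this read-out higher numbers stand for weaker inhibition and lower numbers for stronger inhibition), compound 3 reaches only the limit of the assay, > 20000 nM. Compound 1 `Cc1ccc(C(=O)Nc2cccc(-c3ccnc4c(N)cccc34)c2)cc1C`, which has hydrogen in place of that acetyl, also gives a limit in this assay, > 20000 nM. The step that the two limits leave unreadable from compound 1 to compound 3 therefore cannot be read, since (the limit of > 20000 nM in this assay, at which 2 of the 3 values shown sit). Compound 2 `Nc1cccc2c(-c3cccc(NC(=O)c4cc(Cl)cc(C(F)(F)F)c4)c3)ccnc12` keeps the free amine and has a 3-chloro-5-(trifluoromethyl)phenyl amide; in this assay compound 2 gives 18500 nM, a number rather than a limit. Compound 4 `CC(=O)Nc1cccc2c(-c3cccc(NC(=O)c4ccc(Cl)c(C(F)(F)F)c4)c3)ccnc12` has not been measured; it differs from compound 3 by 4-chloro-3-(trifluoromethyl)phenyl in place of 3,4-dimethylphenyl on a carbonyl carbon. Among the measured compounds shown here, no measured step matches this change directly. The nearest comparison is compound 1 against compound 2, where a different chloro- and trifluoromethyl-bearing ring on the free-amine core moved the result from a limit to a measurable number. For compound 4 a step of an at least 2.2-fold lower number from compound 3 to compound 4 (0.34 log units; beyond the scatter) toward stronger inhibition is therefore expected, though small and uncertain. The estimate for compound 4 in this assay is 9000 nM, within 1500 nM to 20000 nM.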

Compound 4, half-maximal inhibitory concentration: 2400 nM
Compound 4: the middle estimate sits 3.8-fold (0.57 log units) above what was measured; the measured number falls inside the stated range.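

Putting 4-chloro-3-(trifluoromethyl)phenyl in place of 3,4-dimethylphenyl on the carbonyl carbon gives an at least 8.3-fold lower number from compound 3 to compound 4 (0.92 log units; beyond the scatter) in this assay, so the group at this position can change the result on the acetyl-bearing core. Compound 4 is the first compound on that core shown to give a number rather than a limit. The step is only a minimum because compound 3 stands at a limit: the limit of > 20000 nM in this assay, at which 2 of the 4 values shown sit.

The exchange removes both methyl groups and brings in chlorine and trifluoromethyl together, so the compounds shown cannot tell whether one of these groups alone would give the same step. They also leave open what an amine or a carboxylic acid on this ring would do, and how 4-chloro-3-(trifluoromethyl)phenyl would behave on the core with the free amine.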